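The source may report more compounds than this note shows. Statements on the series, on what has been measured and on what is new or still open speak of the compounds shown alone.

Compound 3 `CC[C@H](CCn1cncn1)c1ccc(Cl)cc1` gives 57 ug/mL in an ADME assay on RD cells (Homo sapiens) for cytotoxicity, read by MTT assay, with a stated time of 3 days (on this read-out higher numbers stand for lower toxicity in this test and lower numbers for higher toxicity in this test), the lowest of the three numbers measured. Compound 1 `CC[C@H](CCn1cncn1)c1ccccc1` gives 99.8 ug/mL and compound 2 `CC[C@H](CCn1cncn1)c1ccc(F)cc1` gives 110 ug/mL; the steps of a 1.8-fold lower number from compound 1 to compound 3 (0.24 log units; within the scatter) and a 1.9-fold lower number from compound 2 to compound 3 (0.29 log units; within the scatter) are both within the scatter, as is a 1.1-fold higher number from compound 1 to compound 2 (0.04 log units; within the scatter). Compound 4 `CC[C@H](CCn1cncn1)c1ccc(C)cc1` differs from compound 3 by methyl in place of chloro on an aromatic carbon. Within the data shown here, no measured step exchanges chloro for methyl, so only the small steps around compound 3 bear on it, and no step beyond the scatter is expected in this assay. Compound 4 is therefore expected to give about 75 ug/mL, with a range from 40 ug/mL to 140 ug/mL, meaning an expected step of a 1.3-fold higher number from compound 3 to compound 4 (0.12 log units; within the scatter).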

Compound 4, half-maximal cytotoxic concentration: 85.2 ug/mL
Compound 4: the middle estimate sits 1.1-fold (0.06 log units) below what was measured, and the stated range covers the measured number.
By their numbers in this assay, from the lowest: compounds 3, 4, 1 and 2 (each within the scatter of the next).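

At this place, on an aromatic carbon para to a large group, methyl takes its position among hydrogen, fluoro and chloro in this assay without a step beyond the scatter (with a 1.5-fold higher number from compound 3 to compound 4 (0.17 log units; within the scatter) and a 1.3-fold lower number from compound 2 to compound 4 (0.11 log units; within the scatter) and a 1.2-fold lower number from compound 1 to compound 4 (0.07 log units; within the scatter)). A carbon group therefore joins the halogens here, and the change from chloro to methyl separates compound 3 and compound 4 by no more than repeat measurements would.

From the compounds shown here alone, whether an amine, a carboxylic acid or a longer chain at this place would give a step beyond the scatter stays open. Nothing at hand gives a reason for these numbers.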